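Acyl variation on the carbonyl carbon of the shared core

The source may hold more compounds than are shown below. What is called first, only, known or untested is meant among the compounds shown, and "the series" means these compounds.

Within the data shown here, compound 1 `Cc1nc(S(C)(=O)=O)ccc1Oc1ncnc(OC2CCN(C(=O)OC3(C(F)(F)F)CCC3)CC2)c1F` gives the highest of the three numbers measured so far in a functional assay on isolated protein for inhibition of Glucose-dependent insulinotropic receptor (Rattus norvegicus), read by HTRF and cAMP accumulation (a higher number here means a larger maximal response, a lower number a smaller maximal response), namely 82%. Compound 2 `Cc1nc(S(C)(=O)=O)ccc1Oc1ncnc(OC2CCN(C(=O)SC(C)C)CC2)c1F` gives 81% and compound 3 `Cc1nc(S(C)(=O)=O)ccc1Oc1ncnc(OC2CCN(C(=O)SC3(C)CC3)CC2)c1F` gives 77%; the steps of a number 1 percentage points lower from compound 1 to compound 2 (within the scatter) and a number 5 percentage points lower from compound 1 to compound 3 (within the scatter) both stay within the scatter, as does a number 4 percentage points lower from compound 2 to compound 3 (within the scatter). Compound 4 `Cc1nc(S(C)(=O)=O)ccc1Oc1ncnc(OC2CCN(C(=O)C(C)(C)F)CC2)c1F` differs from compound 1 as follows: a group of 4 heavy atoms (3 carbon, 1 fluorine; no ring) in place of a group of 9 heavy atoms (5 carbon, 1 oxygen, 3 fluorine; one four-membered non-aromatic ring of carbon only), on a carbonyl carbon. The two measured steps from compound 1 replace the same nine-atom group on the same carbonyl carbon with smaller groups and neither moved the read-out beyond the scatter, so no step beyond the scatter is expected here either. Compound 4 is therefore estimated at 79%, with a range of 68% to 89%. This estimate means an expected step of a number 3 percentage points lower from compound 1 to compound 4 (within the scatter).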

Compound 4, largest response reached (reported as efficacy), in percent of the reference or control that the assay uses: 74%
Estimate against measurement, compound 4: 5 percentage points above; low and high end bracket the measured number.
By their numbers in this assay, from the lowest: compounds 4, 3, 2 and 1 (each within the scatter of the next).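

In this assay, 1-fluoro-1-methylethyl on this carbonyl carbon is the first group shown that holds neither oxygen nor sulfur, yet all three new steps stay within the scatter (a number 8 percentage points lower from compound 1 to compound 4 (within the scatter)) (a number 7 percentage points lower from compound 2 to compound 4 (within the scatter)) (a number 3 percentage points lower from compound 3 to compound 4 (within the scatter)). Across these four compounds, the read-out therefore does not separate this group from the earlier ones. No supporting data explain this result.

Going by these compounds, whether an amine or a longer alkyl chain on this carbonyl carbon would stay within the scatter remains open. The compounds shown also leave open how changes elsewhere on the shared core would read.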